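The source may report more compounds than this note shows. Statements on the series, on what has been measured and on what is new or still open speak of the compounds shown alone.

Working notes on the series.

Compound 1 `NS(=O)(=O)c1ccc(NC(=S)Nc2ccc3ncnc(Nc4cccc(Cl)c4)c3c2)cc1` and compound 2 `Cc1cccc(Nc2ncnc3ccc(NC(=S)Nc4ccc(S(N)(=O)=O)cc4)cc23)c1` share a core and differ only in the substituent on the aniline ring. In a functional assay on A549 cells (Homo sapiens) for antiproliferative activity, read by MTT assay, with a stated time of 72 h (a lower number here means a stronger inhibitor, a higher number a weaker inhibitor), compound 1 gives > 40000 nM, which is a limit of the assay and not a number. In this assay compound 2 likewise gives > 40000 nM, again a limit rather than a measured value. Going by the values given here, the single measured step, a step that the two limits leave unreadable from compound 1 to compound 2, therefore cannot be sized, since the limit of > 40000 nM in this assay, at which 2 of the 2 values shown sit, shows that both values sit at the same limit; compound 2 stands at that limit with no numerical value of its own.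

Compound 3 `Cc1ccc(Nc2ncnc3ccc(NC(=S)Nc4ccc(S(N)(=O)=O)cc4)cc23)cc1` is the next variation, with 4-methylphenyl in place of 3-methylphenyl on a nitrogen on an aromatic ring. Among the compounds with values here, no measured step bears directly on this change, and the one step in hand, from compound 1 to compound 2, is itself unreadable, so no direction or size of effect can be derived for this assay; the expectation is that compound 3 stays at the limit. On that basis the estimated step that the limit leaves unreadable from compound 2 to compound 3 is expected to lie within the scatter. Compound 3 is thus expected to give about 50000 nM in this assay, with a range of 15000 nM to 200000 nM, and most probably only a limit will be reported.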

Compound 3, half-maximal inhibitory concentration: 2840 nM
Compound 3: the middle estimate sits 18-fold (1.25 log units) above what was measured; measured number below the stated range.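

In this assay, going by these compounds alone, 4-methylphenyl in place of 3-methylphenyl on a nitrogen on an aromatic ring gives the first measured number, with an at least 14-fold lower number from compound 2 to compound 3 (1.14 log units; beyond the scatter). The two groups have the same atoms, joined differently, so at this place the read-out depends on where the methyl group sits on the phenyl ring and not only on which atoms are present. The change from 3-chlorophenyl to 4-methylphenyl at the same place gives an at least 14-fold lower number from compound 1 to compound 3 (1.14 log units; beyond the scatter), while the step between compound 1 and compound 2 remains unreadable, as both stand at a limit of the assay and not at a number: the limit of > 40000 nM in this assay, at which 2 of the 3 values shown sit.

Going by these compounds, whether the gain is tied to the methyl group itself or would also hold for 4-chlorophenyl or 4-methoxyphenyl on the same nitrogen stays open. Also open, on these data alone, is whether 4-ethylphenyl or 4-carboxyphenyl at this place would keep the activity of compound 3, which gives 2840 nM.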